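This account rests on a few compounds, and the source may have more. Where it says the series, first, only, none or still open, it means among the compounds named here.

Measured so far:
- compound 2, `Cc1ccc(C(=O)Nc2ccc(C#N)cc2)c(O)c1`: 2560 nM
- compound 1, `N#Cc1cccc(NC(=O)c2cc(F)ccc2O)c1`: 9100 nM

Both compounds were tested in a functional assay on KG-1 cells (Homo sapiens) for cytotoxicity, read by luminescence and CellTiter-Glo, with a stated time of 3 days; on this read-out higher numbers stand for weaker inhibition and lower numbers for stronger inhibition. Compound 2 gives 2560 nM, the lowest of the two numbers, while compound 1 gives 9100 nM, a higher number that lies beyond the usual scatter. The two compounds differ in more than one place, so their gap cannot be tied to a single change.

Compound 3, `N#Cc1ccc(NC(=O)c2ccc(Br)cc2O)cc1`, has not yet been measured. It differs from compound 2 in one place: bromo in place of methyl on an aromatic carbon. Among the measured compounds no single-change step of this kind exists, so there is no direct guide to its size. A swap of one small group for another at a position away from the hydroxy group seems unlikely to move the number far; the expectation is a step of about a 1.3-fold lower number from compound 2 to compound 3 (0.11 log units; within the scatter), which is within the scatter, in no clear direction. Compound 3 is therefore estimated at 2000 nM, with a plausible range from 700 nM to 6000 nM.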

Compound 3, half-maximal inhibitory concentration: 1450 nM
Compound 3: middle estimate off by 1.4-fold (0.14 log units), on the high side; measured number inside the range.
By their numbers in this assay, from the lowest: compounds 3 and 2 (each within the scatter of the next); then compound 1.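

In this assay, the first single-change step among these compounds reads a 1.8-fold lower number from compound 2 to compound 3 (0.25 log units; within the scatter), so bromo and methyl cannot be told apart at this position, meta to a hydroxy group and para to a large group. Compound 1 and compound 2 could not show this, as they differ in more than one place, whereas here one position changes alone: one heavy atom replaces another, and the number stays within what repeat measurements would give. Nothing here measures a property that would account for this step, so the result stands as an observation only.

Methyl and bromo each count a single heavy atom, no hydrogen-bond donors or acceptors, and no net charge, so what an amine, a carboxylic acid or a longer chain would do at this position remains open. Also open is which of the differences between compound 1 and compound 2 lies behind the gap between their numbers.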